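Second chloro on the aryl urea: notes before measurement

The compounds below may be only part of what the source reports. "The series", "measured", "known", "first", "only" and "open" are said of these compounds alone.

Measured so far in an ADME assay on HEK293 cells (Homo sapiens) for cytotoxicity, with a stated time of 72 h; a lower number here means that less compound is needed, a higher number that more compound is needed for the effect:
compound 1 `Cc1ccc(NC(=O)Nc2cc(C)nc3ccccc23)cc1` gives > 25000 nM, which is a limit of the assay.
compound 2 `Cc1cc(NC(=O)Nc2cccc(Cl)c2)c2ccccc2n1` gives 21000 nM.
compound 3 `Cc1cc(NC(=O)Nc2cccc(C(N)=O)c2)c2ccccc2n1` gives > 25000 nM, which is a limit of the assay.

Among the compounds with values here, compound 2 stands as the only number among the three; the other two values are limits, as told by the limit of > 25000 nM in this assay, at which 2 of the 3 values shown sit. Two steps that each change one place end or begin at compound 2. The first, an at least 1.1-fold lower number from compound 1 to compound 2 (0.07 log units; that floor lies within the scatter), swaps 3-chlorophenyl for 4-methylphenyl on an amide-type nitrogen. The second, an at least 1.1-fold higher number from compound 2 to compound 3 (0.07 log units; that floor lies within the scatter), puts carbamoyl in place of chloro on an aromatic carbon. Both are floors that lie within the scatter, so neither shows a movement that can be trusted.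

Compound 4 `Cc1cc(NC(=O)Nc2cc(Cl)cc(Cl)c2)c2ccccc2n1` has not yet been measured. It differs from compound 2 by chloro in place of hydrogen on an aromatic carbon. The two measured steps around compound 2 give no direction beyond the scatter, so the step from compound 2 to compound 4 in this assay is expected to stay within the scatter as well, with a real chance that only a limit is returned. Compound 4 is therefore expected near 16000 nM, in the range 6000 nM to 40000 nM. That estimate means an expected step of a 1.3-fold lower number from compound 2 to compound 4 (0.12 log units; within the scatter).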

Compound 4, half-maximal effective concentration: > 25000 nM
Compound 4 ended at the assay's limit; the forecaster's own chance of this, stated with the estimate: 40%; at least 1.5-fold (0.19 log units) between middle value and limit.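

In this assay the added chloro gives an at least 1.1-fold higher number from compound 2 to compound 4 (0.07 log units; that floor lies within the scatter); this floor is the only size that can be stated for the step, and it does not show a movement beyond the scatter. Compound 4 gives > 25000 nM, which is a limit of the assay. New here is that a chloro on this aromatic carbon, meta to a chloro group and meta to a large group, does not yield a second measured number in the series, and compound 2 remains the only compound with one, while the others sit at the same limit: the limit of > 25000 nM in this assay, at which 3 of the 4 values shown sit.

The compounds shown leave open how far the true value of compound 4 lies from that of compound 2, and whether any change on this aryl ring moves the number beyond the scatter in either direction. Also open, going by these compounds, is whether an amine or a carboxylic acid on this aromatic carbon would return a measured number rather than a limit, and whether such a result would hold with the chloro of compound 2 kept in place.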